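Chain extension in a cytotoxicity series on lung cells

The source may hold more compounds than are shown below. What is called first, only, known or untested is meant among the compounds shown, and "the series" means these compounds.

Compound 1 `CCCCCCCCCOC(=O)CCC(=O)N1CCN(CCCOc2cc3c(Nc4ccc(F)c(Cl)c4)ncnc3cc2OC)CC1`: 10.3%
Compound 2 `CCCCCCCCCCOC(=O)CCC(=O)N1CCN(CCCOc2cc3c(Nc4ccc(F)c(Cl)c4)ncnc3cc2OC)CC1`: 3.9%
Compound 3 `CCCCCCCCCCCCOC(=O)CCC(=O)N1CCN(CCCOc2cc3c(Nc4ccc(F)c(Cl)c4)ncnc3cc2OC)CC1`: 2%

These three compounds were read in a functional assay on A549 cells (Homo sapiens) for cytotoxicity, read by MTT assay, with a stated time of 24 h, tested at 60 uM; on this read-out lower numbers stand for a stronger effect and higher numbers for a weaker effect at the one concentration tested. Compound 4 `CCCCCCCCCCCCCOC(=O)CCC(=O)N1CCN(CCCOc2cc3c(Nc4ccc(F)c(Cl)c4)ncnc3cc2OC)CC1` remains to be read in this assay. It differs from compound 3 by methyl in place of hydrogen on a saturated chain carbon, ten or more bonds along the chain from an oxygen next to a carbonyl group. The same kind of change is already seen between compound 1 and compound 2, (methyl in place of hydrogen on a saturated chain carbon, nine bonds along the chain from an oxygen next to a carbonyl group), where it gave a step of a number 6.4 percentage points lower from compound 1 to compound 2 (within the scatter). The two places along the chain are not quite the same, as the two descriptions of the differences show. The two starting points also differ: compound 3 differs from compound 1 by propyl in place of hydrogen on a saturated chain carbon, nine bonds along the chain from an oxygen next to a carbonyl group. Compound 2 to compound 3 gave a number 1.9 percentage points lower from compound 2 to compound 3 (within the scatter). Compound 3 already sits near the floor of the read-out, so a step of no change at the digits printed from compound 3 to compound 4 (within the scatter) is expected, roughly a flat continuation of what the earlier pair showed. Compound 4 is therefore estimated at 2%, between 0% and 10%.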

Compound 4, a percentage reported as activity, at one concentration (the size of the read-out at that concentration, not a potency): 20.6%
Beside the measured number, compound 4's estimate is 18.6 percentage points below it; measured number outside the range, above it.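

In this assay, the methyl change gave a number 18.6 percentage points higher from compound 3 to compound 4 (beyond the scatter), the propyl change gave a number 16.7 percentage points higher from compound 2 to compound 4 (beyond the scatter) and the butyl change gave a number 10.3 percentage points higher from compound 1 to compound 4 (beyond the scatter), so compound 4 does not continue the run of compound 1, compound 2 and compound 3, whose steps all lie within the scatter. Adding the same group therefore does not carry reliably from one core to the next in this series: the same change on two cores in this assay, a number 6.4 percentage points lower (within the scatter) from compound 1 to compound 2 and a number 18.6 percentage points higher (beyond the scatter) from compound 3 to compound 4, 25 percentage points apart, beyond the scatter of two such steps. The propyl change reads alike, but neither comparison shows why the chain of compound 4 behaves differently, and a single compound cannot separate a lasting turn in the series from a result particular to compound 4: the same change on two cores in this assay, a number 8.3 percentage points lower (within the scatter) from compound 1 to compound 3 and a number 16.7 percentage points higher (beyond the scatter) from compound 2 to compound 4, 25 percentage points apart, beyond the scatter of two such steps.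

The compounds shown leave open whether chains longer than that of compound 4 would keep rising in this assay or fall back. They also leave open how a branched alkyl chain, an amide in place of the ester or a terminal carboxylic acid would read.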